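Bromo in place of methyl on a shared core

The source may report more compounds than this note shows. Statements on the series, on what has been measured and on what is new or still open speak of the compounds shown alone.

Compound 1 `CCC(C)Sc1nc2c(cc(-c3ccc(Cl)cc3)n2-c2ccccc2)c(=N)s1` and compound 2 `CCC(C)Sc1nc2c(cc(-c3ccc(C)cc3)n2-c2ccccc2)c(=N)s1` share one core and were both tested in a functional assay on the whole organism for inhibition, with Rattus norvegicus as the target, read by ELISA, with stated times of 30 min and 6 h, at a dose of 30 mg/kg by the oral route; on this read-out lower numbers stand for less inhibition and higher numbers for more inhibition at the one dose given (going by the name of the read-out). In this assay compound 1 gives 2%, and compound 2 gives 2%. Among the compounds with values here, the single measured step, no change at the digits printed from compound 1 to compound 2 (within the scatter), shows that putting methyl in place of chloro on an aromatic carbon left the read-out unchanged. Compound 2 therefore stands level with compound 1 at the digits shown, and both sit at the low end of this read-out, with barely any inhibition at the dose given.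

Compound 3 `CCC(C)Sc1nc2c(cc(-c3ccc(Br)cc3)n2-c2ccccc2)c(=N)s1` has not yet been measured in this assay. It differs from compound 2 by bromo in place of methyl on an aromatic carbon. Within the data shown here, the only step that bears on this change is no change at the digits printed from compound 1 to compound 2 (within the scatter), which was flat within the scatter even though one of the two groups there was also a halogen. On that basis the step of a number 1 percentage points higher from compound 2 to compound 3 (within the scatter) is expected to be none beyond the scatter. Compound 3 is thus expected to give about 3% in this assay, within a range from 0% to 14%.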

Compound 3, a percentage reported as inhibition, in the whole organism at one dose (the size of the read-out at that dose, not a potency): 70%
Compound 3: middle estimate off by 67 percentage points, on the low side; the whole stated range lies below it.
By their numbers in this assay, from the lowest: compounds 1 and 2 (each within the scatter of the next); then compound 3.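

Bromo at this position, on a six-membered aromatic ring of carbon only and para to a large group, gives a number 68 percentage points higher from compound 2 to compound 3 (beyond the scatter) in this assay. What sits on this carbon can therefore matter a great deal, and the earlier pair of compounds gave no sign of that. Bromo in place of chloro gives a number 68 percentage points higher from compound 1 to compound 3 (beyond the scatter) on the same shared core, so the divide does not run between halogens and methyl: compound 1 carries a halogen yet shows the same printed value as compound 2, while compound 3 stands far from both. Nothing measured here explains why bromo stands apart from chloro and methyl.

From the compounds shown here alone, whether the high read-out belongs to bromo alone, or would also appear with iodo, trifluoromethyl, methoxy or an amine on this carbon, stays open. Going by these compounds, it is also open whether the 4-bromophenyl group would keep this effect on a changed core or at other doses, since each compound here has a reading at a single dose.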